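This account rests on a few compounds, and the source may have more. Where it says the series, first, only, none or still open, it means among the compounds named here.

For the measured compounds named here, compound 1 `CC[C@@H](C)[C@H](NC(=O)c1ccc(C(CC)(CC)c2ccc(OCC(=O)C(C)(C)C)c(C)c2)n1CC)C(=O)OC` gives 590 nM in an assay on HL-60 cells for agonist activity at vitamin D3 receptor (Homo sapiens), read by microscopy, with a stated time of 96 h (on this read-out lower numbers stand for an effect already at smaller amounts and higher numbers for an effect only at larger amounts of compound), the highest number among the three compounds measured so far. Compound 2 `CCn1c(C(=O)NCCCN(C)C)ccc1C(CC)(CC)c1ccc(OCC(=O)C(C)(C)C)c(C)c1` gives 96 nM in this assay, and compound 3 `CCn1c(C(=O)NCCN)ccc1C(CC)(CC)c1ccc(OCC(=O)C(C)(C)C)c(C)c1` gives 120 nM. Both measured steps away from compound 1 replace the same group on the amide-type nitrogen: a 6.1-fold lower number from compound 1 to compound 2 (0.79 log units; beyond the scatter), and a 4.9-fold lower number from compound 1 to compound 3 (0.69 log units; beyond the scatter). Between the two amine-bearing chains the numbers are indistinguishable: a 1.3-fold higher number from compound 2 to compound 3 (0.10 log units; within the scatter).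

Compound 4 `C=CCN(C)C(=O)c1ccc(C(CC)(CC)c2ccc(OCC(=O)C(C)(C)C)c(C)c2)n1CC` is the next variation at the same position. allyl(methyl)amino in place of (1-(methoxycarbonyl)-2-methylbutyl)amino on a carbonyl carbon As in the two measured steps, the 1-(methoxycarbonyl)-2-methylbutyl group leaves, but here the entering group carries no hydrogen-bond donor or acceptor and no defined stereocentre, so neither measured step matches it closely. Both bear on it only in showing that removing this group has so far given a modest lowering. A smaller lowering than in those steps is expected, a 2.4-fold lower number from compound 1 to compound 4 (0.37 log units; beyond the scatter), giving for compound 4 an estimated 250 nM in this assay, in the range 80 nM to 800 nM.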

Compound 4, half-maximal effective concentration: 21600 nM
For compound 4 the middle estimate is 86-fold (1.94 log units) below the measured one; measured number outside the range, above it.
By their numbers in this assay, from the lowest: compounds 2 and 3 (each within the scatter of the next); then compound 1; then compound 4.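

For the compounds shown here, at the carbonyl carbon, losing the (1-(methoxycarbonyl)-2-methylbutyl)amino group does not by itself lower the number in this assay, since allyl(methyl)amino in its place gives a 37-fold higher number from compound 1 to compound 4 (1.56 log units; beyond the scatter) and reverses the direction of the earlier steps. The same entering group stands further still from the two amine-bearing chains, with a 180-fold higher number from compound 3 to compound 4 (2.26 log units; beyond the scatter) and a 230-fold higher number from compound 2 to compound 4 (2.35 log units; beyond the scatter), so this position tolerates some amide substituents far better than others. Among these four compounds, only compound 4 has an entering group with no hydrogen-bond donor, but nothing available ties the rise to that or any other feature.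

Allyl and methyl enter together, so their separate contributions remain unresolved. Plain allylamino and methylamino groups at this carbonyl carbon would separate them and show whether keeping the amide hydrogen matters.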